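This account rests on a few compounds, and the source may have more. Where it says the series, first, only, none or still open, it means among the compounds named here.

Within the data shown here, compound 1 `S=C(Nc1ccccc1)N1N=C(c2ccccc2)CC1c1ccc2c(c1)OCCO2` gives 1850 nM in a functional assay on A-375 cells (Homo sapiens) for antiproliferative activity, read by MTT assay, with a stated time of 48 h (on this read-out higher numbers stand for weaker inhibition of growth and lower numbers for stronger inhibition of growth), the lower of the two numbers measured so far. Among the measured compounds shown here, its one measured neighbour, compound 2 `CSc1ccc(C2=NN(C(=S)Nc3ccccc3)C(c3ccc4c(c3)OCCO4)C2)cc1`, gives 159000 nM in this assay; the step of an 86-fold higher number from compound 1 to compound 2 (1.93 log units; beyond the scatter) came from methylsulfanyl in place of hydrogen on an aromatic carbon. Compound 3 `O=[N+]([O-])c1ccc(C2=NN(C(=S)Nc3ccccc3)C(c3ccc4c(c3)OCCO4)C2)cc1` carries instead (nitro in place of hydrogen on an aromatic carbon); the same difference, cut one bond further out, reads phenyl to 4-nitrophenyl, and the group enters para to a large group. For the measured compounds named here, the only measured step that bears on this change is an 86-fold higher number from compound 1 to compound 2 (1.93 log units; beyond the scatter), which is large and runs toward weaker inhibition of growth; it concerns a different group at the same place, so it is a guide to direction more than to size. On that single precedent, compound 3 is expected to sit well above compound 1 in this assay. Compound 3 is therefore expected to show a step of an 11-fold higher number from compound 1 to compound 3 (1.03 log units; beyond the scatter), toward weaker inhibition. The value of compound 3 is estimated at 20000 nM, with a range from 3000 nM to 130000 nM.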

Compound 3, concentration for 50% growth inhibition: 78100 nM
Estimate against measurement, compound 3: 3.9-fold (0.59 log units) below; the range from low to high includes it.
By their numbers in this assay, from the lowest: compound 1; then compound 3; then compound 2.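

With nitro as a second group at this place on the aromatic ring, para to a large group, this assay again shows a large rise, a 42-fold higher number from compound 1 to compound 3 (1.63 log units; beyond the scatter), so the rise seen earlier is not confined to methylsulfanyl, and compound 1, which carries only hydrogen there, keeps the lowest number of the three. The two substituted compounds lie much closer to each other than either does to compound 1: exchanging methylsulfanyl for nitro gives only a 2.0-fold lower number from compound 2 to compound 3 (0.31 log units; beyond the scatter), a modest step though beyond the scatter, so at this place the choice between these two groups counts for far less than the replacement of hydrogen by either of them. No measurement on hand bears on what lies behind these steps, and the numbers record only their size and direction.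

The compounds shown leave open whether the same rise would follow from a smaller group such as fluorine or methyl, or from an amine or a carboxylic acid at this place. They also leave open whether any group on this ring could bring the number below that of compound 1, and whether the same change would give a similar step at another position on the ring.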